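The compounds below may be only part of what the source reports. "The series", "measured", "known", "first", "only" and "open" are said of these compounds alone.

Compound 1 `COc1cc[nH]c1/C=C1\C(=O)Nc2ccc([N+](=O)[O-])c(N3CC[C@@H](N)C3)c21` — in a functional assay on MDA-MB-435 cells (Homo sapiens) for antiproliferative activity, read by MTT assay, with a stated time of 5 days (a lower number here means a stronger inhibitor, a higher number a weaker inhibitor), compound 1 gives < 10 nM, which is a limit of the assay rather than a number.
Compound 2 `COc1cc[nH]c1/C=C1\C(=O)Nc2ccc([N+](=O)[O-])c(N3CC[C@@H](O)C3)c21` — compound 2 gives 88 nM.
Compound 3 `COc1cc[nH]c1/C=C1\C(=O)Nc2ccc(F)cc21` — compound 3 gives > 30000 nM, again a limit of the assay.

Among the compounds with values here, compound 2 thus holds the only plain number among the three; the other two sit at a limit, one at the limit of < 10 nM in this assay, at which 1 of the 3 values shown sits, and one at the limit of > 30000 nM in this assay, at which 1 of the 3 values shown sits. Within the data shown here, the single measured step, an at least 8.8-fold higher number from compound 1 to compound 2 (0.94 log units; beyond the scatter), concerns a different change. Compound 4 `COc1cc[nH]c1/C=C1\C(=O)Nc2ccc([N+](=O)[O-])c(N3CCCC(O)C3)c21` differs from compound 2 by 3-hydroxypiperidin-1-yl in place of 3-hydroxypyrrolidin-1-yl on an aromatic carbon. Among the measured compounds shown here, no measured step covers such a ring-size change, so only a modest shift, if any, is expected, a 1.7-fold higher number from compound 2 to compound 4 (0.23 log units; within the scatter). Compound 4 is therefore estimated at 150 nM, between 40 nM and 600 nM.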

Compound 4, half-maximal inhibitory concentration: 250 nM
Compound 4: middle estimate off by 1.7-fold (0.22 log units), on the low side, and the stated range covers the measured number.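

With the hydroxy group kept, the six-membered ring gives a weaker inhibitor (a 2.8-fold higher number from compound 2 to compound 4 (0.45 log units; beyond the scatter)), though compound 4 also has no defined stereocentre, so ring size is not the only difference. Placing 3-hydroxypiperidin-1-yl where 3-aminopyrrolidin-1-yl stood gives a larger step (an at least 25-fold higher number from compound 1 to compound 4 (1.39 log units; beyond the scatter)). That step rests on a limit of the assay, held by compound 1: the limit of < 10 nM in this assay, at which 1 of the 4 values shown sits.

Still open, from the compounds shown here alone, is whether 3-aminopiperidin-1-yl would stay close to compound 1 or follow compound 4. An open-chain group such as 2-aminoethylamino at this position also remains untested among the compounds shown.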